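This account rests on a few compounds, and the source may have more. Where it says the series, first, only, none or still open, it means among the compounds named here.

Measured so far in an ADME assay on the whole organism with Oryza sativa as the target, tested at 0.1 uM; a higher number here means a weaker effect of the compound at the concentration tested, a lower number a stronger effect:
compound 1, `C[C@H](NC(=O)Nc1cccc(F)c1)c1ccccc1`, gives 97%
compound 2, `C[C@@H](NC(=O)Nc1ccc(F)cc1)c1ccccc1`, gives 98%
compound 3, `C[C@H](NC(=O)Nc1cccc(F)c1F)c1ccccc1`, gives 100%

Compound 1 and compound 2 have the same atoms joined differently; the difference between the two cores is not broken down here. Their two values lie within the scatter of each other, as does the value of compound 3 against either.

From compound 1 to compound 3 the change is fluoro in place of hydrogen on an aromatic carbon, and the step is a number 3 percentage points higher from compound 1 to compound 3 (within the scatter).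

Compound 4, `C[C@@H](NC(=O)Nc1ccc(F)cc1F)c1ccccc1`, is not yet measured. It differs from compound 2 by fluoro in place of hydrogen on an aromatic carbon. This is the same kind of change as from compound 1 to compound 3, but not the same: in compound 3 the entering fluoro is ortho to a fluoro group and ortho to a large group, whereas in compound 4 it is ortho to a large group and meta to a fluoro group.

Because a number 3 percentage points higher from compound 1 to compound 3 (within the scatter) stayed within the scatter, the step of a number 1 percentage points higher from compound 2 to compound 4 (within the scatter) is expected to be of similar size. Compound 4 is estimated at 99%, between 92% and 100%.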

Compound 4, a percentage reported as activity, at one concentration (the size of the read-out at that concentration, not a potency): 100%
For compound 4 the middle estimate is 1 percentage points below the measured one, within the range that was stated.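

Set on the core of compound 2 in this assay, the fluoro gives a number 2 percentage points higher from compound 2 to compound 4 (within the scatter) and matches what the same change did on the other core, as far as two such steps can be compared: the same change on two cores in this assay, a number 3 percentage points higher (within the scatter) from compound 1 to compound 3 and a number 2 percentage points higher (within the scatter) from compound 2 to compound 4, 1 percentage points apart, within the scatter of two such steps. Carried between these two cores, fluoro in place of hydrogen on an aromatic carbon thus leaves the read-out within the scatter both times, even though the entering fluoro stands in a different place relative to the fluoro already present. This does not show a step of fixed size, and two small steps say nothing about how the change would behave on a core with a clearly stronger effect.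

The compounds shown carry only fluoro as a ring substituent, so it remains open whether chloro, methoxy, trifluoromethyl or an amine in its place would move the read-out beyond the scatter. Also open, as far as these compounds go, is what a longer chain in place of the methyl group would do.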